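Methyl Ester in Place of Acid on a Cytotoxicity Read-out

The compounds below may be only part of what the source reports. "The series", "measured", "known", "first", "only" and "open" are said of these compounds alone.

Compound 1, `COc1cccc(OC)c1C(=O)Nc1c[nH]nc1C(=O)O`: > 50000 nM
Compound 2, `CO[C@H]1CC[C@H](NC(=O)c2n[nH]cc2NC(=O)c2ccccc2)CC1`: 800 nM

Of the compounds shown here, two have been measured in an ADME assay on MRC5 cells (Homo sapiens) for inhibition, with a stated time of 72 h; on this read-out lower numbers stand for an effect already at smaller amounts and higher numbers for an effect only at larger amounts of compound. Compound 1 gives > 50000 nM, which is a limit of the assay and not a number, so for compound 1 only a bound is known: it sits at the limit of > 50000 nM in this assay, at which 1 of the 2 values shown sits. Compound 2, built on the same core but with a different amide partner, gives 800 nM in this assay, a numerical value.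

Compound 3, `COC(=O)c1n[nH]cc1NC(=O)c1c(OC)cccc1OC`, has not yet been measured. It differs from compound 1 in one place, (methyl in place of hydrogen on an oxygen next to a carbonyl group). Among the measured compounds shown here, because compound 1 stands at the limit of > 50000 nM in this assay, at which 1 of the 2 values shown sits, no step between measured compounds is available to anchor the size of the change. The expectation is that the step from compound 1 to compound 3 in this assay points toward lower numbers, with a fair chance that compound 3 again reaches only the limit. For compound 3 the estimate in this assay is 20000 nM, in a range from 4000 nM to 50000 nM, which corresponds to an expected at least 2.5-fold lower number from compound 1 to compound 3 (0.39 log units; beyond the scatter).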

Compound 3, half-maximal effective concentration: > 50000 nM
Compound 3 gave a limit, no number (the forecaster's own chance of this, stated with the estimate: 45%); at least 2.5-fold (0.39 log units) between middle value and limit.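

In this assay compound 1 and compound 3 each give only a limit and not a number, so the step between them cannot be read. Both compounds sit at the same limit: the limit of > 50000 nM in this assay, at which 2 of the 3 values shown sit. Left open is whether methyl in place of hydrogen on an oxygen next to a carbonyl group changes this read-out at all, and by how much.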